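Esterifying the acid of compound 2: expected cytotoxicity

The source may hold more compounds than are shown below. What is called first, only, known or untested is meant among the compounds shown, and "the series" means these compounds.

Compound 2 `COc1cccc(-c2ccc(C(=O)N(Cc3cccc(OCCCCCC(=O)O)c3)C(C)C)cc2)c1` was tested in an ADME assay on BJ cells (Homo sapiens) for cytotoxicity, read by CellTiter-Glo and resazurin assay, with a stated time of 72 h; on this read-out higher numbers stand for an effect only at larger amounts of compound and lower numbers for an effect already at smaller amounts. In that assay compound 2 reaches only a limit, > 20900 nM. Compound 1 `CC(C)N(Cc1cccc(OCCCCCC(=O)O)c1)C(=O)c1ccc(-c2cccc(Oc3ccccc3)c2)cc1` likewise gives only a limit, > 18700 nM. Compound 3 `CC(C)N(Cc1cccc(OCCCCCC(=O)O)c1)C(=O)c1ccc(-c2ccc(Cl)c(Cl)c2)cc1` also gives only a limit, > 26000 nM. The steps a step that the two limits leave unreadable from compound 1 to compound 2 and a step that the two limits leave unreadable from compound 2 to compound 3 thus have no readable size, since every value shown sits at a limit (the limit of > 18700 nM in this assay, at which 1 of the 3 values shown sits, (the limit of > 20900 nM in this assay, at which 1 of the 3 values shown sits), (the limit of > 26000 nM in this assay, at which 1 of the 3 values shown sits)). Compound 4 `CCOC(=O)CCCCCOc1cccc(CN(C(=O)c2ccc(-c3cccc(OC)c3)cc2)C(C)C)c1` differs from compound 2 by ethyl in place of hydrogen on an oxygen next to a carbonyl group. For the measured compounds named here, none of the measured steps bears on this change, and none of them is readable anyway, so no step beyond the scatter is expected a step that the limit leaves unreadable from compound 2 to compound 4. Compound 4 is therefore estimated at about 25000 nM, within 8000 nM to 60000 nM, most likely reported again as a limit.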

Compound 4, half-maximal effective concentration: > 21000 nM
Compound 4: only a limit was reported (the forecaster's own chance of this, stated with the estimate: 70%); the middle value does not contradict the limit.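

Compound 2 and compound 4 both gave only limits, so the step between them cannot be read. The compounds shown leave open whether ethyl in place of hydrogen on that oxygen changes cytotoxicity at all, and at what concentration any of them would show a half-maximal effect.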